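Trifluoromethyl for chloro on a triazole at the limit

The source may report more compounds than this note shows. Statements on the series, on what has been measured and on what is new or still open speak of the compounds shown alone.

Compound 1 `C=C1C[C@]23C[C@@]1(O)CC[C@H]2c1ccc(OS(=O)(=O)c2ccc(C)cc2)c(C)c1[C@@H]3Cn1cc(-c2ccc(Cl)cc2)nn1` gives > 20000 nM in a functional assay on SMMC-7721 cells (Homo sapiens) for cytotoxicity, read by MTT assay, with a stated time of 4 days; a higher number here means a weaker inhibitor, a lower number a stronger inhibitor.
Compound 2 `C=C1C[C@]23C[C@@]1(O)CC[C@@H]2c1cccc(C)c1[C@@H]3Cn1cc(-c2ccc(Cl)cc2)nn1` gives > 20000 nM in this assay.
Compound 3 `C=C1C(=O)[C@]23C[C@@]1(O)CC[C@H]2c1ccc(OS(=O)(=O)c2ccc(C)cc2)c(C)c1[C@@H]3Cn1cc(-c2ccc(F)cc2)nn1` gives 4280 nM in this assay.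

Compound 2 stands on a limit of the assay, not on a number, and it is joined there by compound 1. Compound 3 is the only one of the three that returns a number in this assay. Compound 2 thus belongs to the group described by the limit of > 20000 nM in this assay, at which 2 of the 3 values shown sit, and nothing finer than that can be said about where it lies.

Compound 4 `C=C1C[C@]23C[C@@]1(O)CC[C@@H]2c1cccc(C)c1[C@@H]3Cn1cc(-c2ccc(C(F)(F)F)cc2)nn1` is the next member to be tested. It differs from compound 2 in one place: trifluoromethyl in place of chloro on an aromatic carbon. Within the data shown here, no pair of measured compounds differs by this change or by anything like it, so there is no measured step to lean on. With the starting point already beyond the reach of the assay, the expectation is for no movement beyond the scatter, and a fair chance that compound 4 again returns only a limit. The expected step that the limit leaves unreadable from compound 2 to compound 4 is therefore treated as essentially flat. Compound 4 is estimated at 25000 nM in this assay, with a range from 8000 nM to 80000 nM.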

Compound 4, half-maximal inhibitory concentration: > 20000 nM
Compound 4: a limit, no number (the forecaster's own chance of this, stated with the estimate: 70%); the middle value lies beyond the limit too.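

Among these compounds, compound 4 returns only a limit in this assay, as compound 2 does, so no step between them can be read: the limit of > 20000 nM in this assay, at which 3 of the 4 values shown sit.
The compounds shown leave open whether trifluoromethyl in place of chloro changes cytotoxicity at all, and how far beyond the limit either compound lies.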